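Epimer at the ring carbon: compound 1 to compound 4

The source may report more compounds than this note shows. Statements on the series, on what has been measured and on what is new or still open speak of the compounds shown alone.

Measured so far in an ADME assay on microsomes from liver (Mus musculus) for metabolic stability, read by LC-MS, with a stated time of 10 min; a lower number here means that less of the compound is left, a higher number that more of the compound is left:
compound 1 `CN(C[C@@H]1Cc2c(cccc2N2CCNCC2)CN1)[C@H]1CCCc2cccnc21` — 54.6%
compound 2 `CN(C[C@H]1Cc2c(cccc2N2CCN(C3CC3)CC2)CN1)[C@H]1CCCc2cccnc21` — 7%
compound 3 `CN(C[C@H]1Cc2c(cccc2N2C[C@@H]3C[C@H]2CN3)CN1)[C@H]1CCCc2cccnc21` — 36.3%

Compound 1 stands highest of the three in this assay; its gaps to compound 3 and to compound 2 are both beyond the scatter. Going by the values given here, the only single-point step measured so far, a number 29.3 percentage points higher from compound 2 to compound 3 (beyond the scatter), swaps one ring group for another on the aromatic carbon and says nothing about configuration. Compound 4 `CN(C[C@H]1Cc2c(cccc2N2CCNCC2)CN1)[C@H]1CCCc2cccnc21` differs from compound 1 by the two compounds have the same atoms and bonds and differ only in configuration as drawn: 1 of 2 stereo elements differ; a stereocentre at a saturated ring carbon is drawn S in compound 1 and R in compound 4. Among the compounds with values here, compounds 2 and 3 share that configuration with compound 4 but differ elsewhere, so no measured step bears on this change. The step of a number 9.6 percentage points lower from compound 1 to compound 4 (within the scatter) is therefore expected to stay within or near the scatter. For compound 4 the estimate in this assay is 45%, expected between 20% and 70%.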

Compound 4, percent of the compound remaining: 19.9%
For compound 4 the middle estimate is 25.1 percentage points above the measured one, outside the stated range (below it).
By their numbers in this assay, from the lowest: compound 2; then compound 4; then compound 3; then compound 1.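

In this assay the stereocentre at the saturated ring carbon matters on its own, with a number 34.7 percentage points lower from compound 1 to compound 4 (beyond the scatter), and this step can be assigned to configuration alone: the fact that compounds 1 and 4 differ only in the configuration as drawn. Among the compounds drawn R there, hydrogen in place of cyclopropyl gives a number 12.9 percentage points higher from compound 2 to compound 4 (beyond the scatter), and the exchange of one ring group for another on the aromatic carbon gives a number 16.4 percentage points lower from compound 3 to compound 4 (beyond the scatter).

From the compounds shown here alone, whether S also gives the higher number with the cyclopropyl or the group of 7 heavy atoms remains open. So does the effect of a methyl or an acetyl on that amine nitrogen in either configuration.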